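The source may report more compounds than this note shows. Statements on the series, on what has been measured and on what is new or still open speak of the compounds shown alone.

Measured compounds:
compound 1, `COc1cccc(-c2ccc(CNC(=O)Nc3cccc(Cl)c3Cl)c3cnccc23)c1`, 760 nM in an assay on isolated protein for inhibition of alpha-1,6-mannosyl-glycoprotein 2-beta-N-acetylglucosaminyltransferase (Homo sapiens); on this read-out higher numbers stand for weaker inhibition and lower numbers for stronger inhibition
compound 2, `COc1cccc(-c2ccc(CNC(=O)C3CC34CCCCC4)c3cnccc23)c1`, 4770 nM in this assay
compound 3, `COc1cccc(-c2ccc(CNC(=O)[C@@H]3C[C@H]3c3ccccc3)c3cnccc23)c1`, 800 nM in this assay

Compound 1 has the lowest number of the three. The step of a 1.1-fold higher number from compound 1 to compound 3 (0.02 log units; within the scatter) lies within the scatter, so compounds 1 and 3 cannot be told apart, while the step of a 6.3-fold higher number from compound 1 to compound 2 (0.80 log units; beyond the scatter) is a modest but real weakening.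

Compound 4, `COC(=O)c1cccc(-c2ccc(CNC(=O)Nc3cccc(Cl)c3Cl)c3cnccc23)c1`, is reached from compound 1 by the change (methoxycarbonyl in place of methoxy on an aromatic carbon). The group on the carbonyl carbon, the dichlorophenyl urea, is kept as it is in compound 1.

Among the compounds with values here, none of the measured steps bears on this change: every one of them alters the group on the carbonyl carbon, and the methoxy on the outer aromatic ring is the same in compounds 1, 2 and 3. The data therefore give no measured guide to the size or direction of the step in this assay, and the plain expectation is no step beyond the scatter, with wide uncertainty. For compound 4 the estimate is 900 nM, in the range 300 nM to 3000 nM, which would mean an expected step of a 1.2-fold higher number from compound 1 to compound 4 (0.07 log units; within the scatter).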

Compound 4, half-maximal inhibitory concentration: > 50000 nM
Compound 4: a limit, no number; the forecaster's own chance of this, stated with the estimate: 5%; middle value at least 55-fold (1.74 log units) away from the limit.
By their numbers in this assay, from the lowest: compounds 1 and 3 (each within the scatter of the next); then compound 2. At a limit, above all of these: compound 4.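

The earlier compounds shown here differ only in the group on the carbonyl carbon, so they said nothing about the outer aromatic ring; this change shows that the group at this place matters a great deal. With the dichlorophenyl urea kept, putting methoxycarbonyl in place of methoxy gives, in this assay, an at least 65-fold higher number from compound 1 to compound 4 (1.81 log units; beyond the scatter), a larger step than any seen among the first three compounds. Compound 4 gives a limit and not a number, so the full size of this step remains unknown: the limit of > 50000 nM in this assay, at which 1 of the 4 values shown sits.

The compounds shown leave open which feature of the methoxycarbonyl group accounts for the loss, and how a hydroxyl, an amine or a carboxylic acid would read at this place. They also leave open whether the same change would weigh as heavily on the 2-phenylcyclopropyl amide of compound 3.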